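The compounds below may be only part of what the source reports. "The series", "measured", "known", "first", "only" and "open" are said of these compounds alone.

Measured compounds:
compound 1, `CC(C)(Oc1ccc(NCc2cccc(Oc3ccccc3)c2)cc1)C(=O)O` — in a functional assay on CHO cells for agonist activity at Free fatty acid receptor 1 (Homo sapiens) (on this read-out higher numbers stand for an effect only at larger amounts of compound and lower numbers for an effect already at smaller amounts), compound 1 gives < 10000 nM, a limit of the assay.
compound 2, `O=C(O)[C@H]1C[C@@H]1c1ccc(NCc2cccc(Oc3ccccc3)c2)cc1` — in this assay compound 2 gives 12.3 nM; 13.5 nM (2 entries).

Compound 1 stands only as a limit in this assay: the entry is no single number, see (the limit of < 10000 nM in this assay, at which 1 of the 2 values shown sits). Going by the values given here, compound 2 is the one measured compound with a number here, with agreeing entries, see (the several entries of compound 2 in this assay, 12.3 nM; 13.5 nM (2 entries)). Among the compounds with values here, no step between measured compounds joins the two, so the numbers say only that compound 1 sits somewhere under its limit and compound 2 at a firm low concentration.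

Compound 3, `CC(CC(=O)O)c1ccc(NCc2cccc(Oc3ccccc3)c2)cc1`, is not yet measured. It differs from compound 1 by 1-(carboxymethyl)ethyl in place of 1-carboxy-1-methylethoxy on an aromatic carbon, with the rest of the shared core kept. Within the data shown here, no measured step of this kind exists, so the size of the step from compound 1 to compound 3 in this assay is an expectation only. Compound 3 is expected to give a real number rather than a limit, with a step that the limit leaves unreadable from compound 1 to compound 3 taken from the limit. The estimate for compound 3 in this assay is 60 nM, ranging from 10 nM to 400 nM.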

Compound 3, half-maximal effective concentration: 126 nM
For compound 3 the middle estimate is 2.1-fold (0.32 log units) below the measured one, within the range that was stated.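

No new step can be read in this assay: the change from compound 1 to compound 3 has no readable size. Compound 1 gives < 10000 nM, which is a limit and not a number. The compounds shown leave open how much replacing 1-carboxy-1-methylethoxy with 1-(carboxymethyl)ethyl on the shared core changes the read-out.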